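The source may hold more compounds than are shown below. What is called first, only, known or untested is meant among the compounds shown, and "the series" means these compounds.

Among the compounds with values here, compound 1 `Cc1ccc(C(=O)NCN2CCC(c3cccc[n+]3[O-])CC2)cc1C` and compound 2 `Cc1cccc(NC(=O)CN2CCC(c3cccc(C#N)n3)CC2)c1` are the two measured members. In a functional assay on HEK293 cells for agonist activity at D(4) dopamine receptor (Homo sapiens), read by FLIPR (on this read-out lower numbers stand for an effect already at smaller amounts and higher numbers for an effect only at larger amounts of compound), compound 1 gives 38 nM and compound 2 gives 36 nM, and the two numbers lie within the scatter of each other, so neither stands apart. Within the data shown here, no pair of measured compounds differing in a single place is available. On these data alone, compound 3 `O=C(NCN1CCC(c2cccc[n+]2[O-])CC1)c1cc(Cl)cc(Cl)c1` is untested and differs from compound 1 by 3,5-dichlorophenyl in place of 3,4-dimethylphenyl on a carbonyl carbon. The step from compound 1 to compound 3 is expected to be a 1.1-fold higher number from compound 1 to compound 3 (0.02 log units; within the scatter), not beyond the scatter in either direction. Compound 3 is accordingly estimated at 40 nM, with a range from 12 nM to 130 nM.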

Compound 3, half-maximal effective concentration: 45 nM
For compound 3 the middle estimate is 1.1-fold (0.05 log units) below the measured one, and the stated range covers the measured number.
By their numbers in this assay, from the lowest: compounds 2, 1 and 3 (each within the scatter of the next).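

Swapping 3,4-dimethylphenyl for 3,5-dichlorophenyl on a carbonyl carbon gives in this assay a 1.2-fold higher number from compound 1 to compound 3 (0.07 log units; within the scatter) and so stays within the scatter. This first single-place comparison in the series shows that this read-out does not separate these two groups at this position. No available evidence bears on this result.

Still open, on these data alone, is whether a cyclohexyl ring or a phenyl ring carrying a carboxylic acid on the same carbonyl carbon would also stay within the scatter of compound 1. As far as these compounds go, how changes elsewhere in the core of compound 1 would read also remains open.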